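The source may hold more compounds than are shown below. What is called first, only, known or untested is meant among the compounds shown, and "the series" means these compounds.

Among the compounds with values here, only two compounds have been measured so far, so this story starts from very little. In a functional assay on the whole organism with Mus musculus as the target (a higher number here means that more compound is needed for the effect, a lower number that less compound is needed), compound 1 `CNC(=O)/C(C)=C/c1cccc(C(F)(F)F)c1` gives 75 mg/kg. In the same test compound 2 `CN1C(=O)CCC1(O)c1cccc(C(F)(F)F)c1` gives 129 mg/kg. These two numbers lie within the usual scatter of each other, so compound 2 stands level with compound 1 on the evidence available.

The next compound keeps the shared core of compound 2 and changes one place. Compound 3 `CCCCN1C(=O)CCC1(O)c1cccc(C(F)(F)F)c1` has propyl in place of hydrogen on a saturated chain carbon bound to an amide-type nitrogen in a ring, so that the same difference, cut one bond further out, reads methyl to butyl (propyl in place of hydrogen on a saturated chain carbon bound to an amide-type nitrogen in a ring).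

Within the data shown here, no pair of measured compounds differs in just one place, so the data offer no direct precedent for this change. The expectation therefore starts from compound 2 at 129 mg/kg, and no step beyond the scatter is expected, in either direction. The estimated step is a 1.2-fold lower number from compound 2 to compound 3 (0.07 log units; within the scatter). For compound 3 the expected dose in this assay is 110 mg/kg, with an estimated range from 50 mg/kg to 240 mg/kg.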

Compound 3, dose for half-maximal effect: > 200 mg/kg
Compound 3 ended at the assay's limit (the forecaster's own chance of this, stated with the estimate: 10%); at least 1.8-fold (0.25 log units) between middle value and limit.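

In this assay compound 3 reaches a limit of the assay, so its reading is a boundary and not a number: the limit of > 200 mg/kg in this assay, at which 1 of the 3 values shown sits. Putting propyl in place of hydrogen on a saturated chain carbon bound to an amide-type nitrogen in a ring, which reads as methyl to butyl, gives an at least 1.5-fold higher number from compound 2 to compound 3 (0.19 log units; that floor lies within the scatter); the real step could be larger, but the part that can be stated does not go beyond the usual scatter. Within the data shown here, this is the first comparison in the story where only one place differs, and this single pair gives no sign that the longer butyl chain reduces the dose needed, while leaving the true size of the step unknown.

As far as these compounds go, how the dose would respond to a chain of intermediate length such as ethyl, or to a chain ending in an amine or a carboxylic acid, stays open. Among these compounds, with only one pair at this place, it also remains open whether any trend with chain length exists at all, or whether the same change would behave alike on another core.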